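This account rests on a few compounds, and the source may have more. Where it says the series, first, only, none or still open, it means among the compounds named here.

Working notes on the aryl ketone series.

Among the measured compounds shown here, compound 1 `C=C(Br)C(=O)Nc1ccc(/C=C/C(=O)c2ccccc2)cc1` in a functional assay on MOLT-4 cells (Homo sapiens) for antiproliferative activity, with a stated time of 48 h (on this read-out lower numbers stand for stronger inhibition and higher numbers for weaker inhibition), gives 3100 nM and stands highest of the two numbers so far. For the measured compounds named here, its only measured neighbour is compound 2 `C=C(Br)C(=O)Nc1ccc(/C=C/C(=O)c2ccc(F)cc2)cc1`, which in this assay gives 660 nM, the change being a 4.7-fold lower number from compound 1 to compound 2 (0.67 log units; beyond the scatter), a fluoro in place of hydrogen on an aromatic carbon of the ring attached to the carbonyl.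

Compound 3 `C=C(Br)C(=O)Nc1ccc(/C=C/C(=O)c2cccs2)cc1` differs from compound 1 in that same ring: thiophen-2-yl in place of phenyl on a carbonyl carbon. Going by the values given here, no measured step exchanges one aromatic ring for another here; the only step that touches this position is the fluoro substitution from compound 1 to compound 2, which moved the number by a 4.7-fold lower number from compound 1 to compound 2 (0.67 log units; beyond the scatter). That step shows the ring is a place where change registers beyond the scatter, but says nothing about the direction for a thiophen-2-yl in place of phenyl.

The expectation is therefore a step of a 1.6-fold lower number from compound 1 to compound 3 (0.19 log units; within the scatter), small and uncertain in direction. Compound 3 is estimated at 2000 nM in this assay, within a range of 500 nM to 8000 nM.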

Compound 3, half-maximal inhibitory concentration: 550 nM
Beside the measured number, compound 3's estimate is 3.6-fold (0.56 log units) above it, within the range that was stated.
By their numbers in this assay, from the lowest: compounds 3 and 2 (each within the scatter of the next); then compound 1.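

In this assay, thiophen-2-yl in place of phenyl on a carbonyl carbon gives a 5.6-fold lower number from compound 1 to compound 3 (0.75 log units; beyond the scatter), so exchanging the whole aromatic ring registers beyond the scatter and runs the same way as the fluoro substitution, which gave a 4.7-fold lower number from compound 1 to compound 2 (0.67 log units; beyond the scatter). The two changes cannot be told apart here, as thiophen-2-yl in place of 4-fluorophenyl gives a 1.2-fold lower number from compound 2 to compound 3 (0.08 log units; within the scatter), which leaves the plain phenyl of compound 1 as the weakest of the three, with both other groups standing level. Nothing available explains either step.

The compounds shown leave open how other groups would stand on this carbonyl carbon, such as furan-2-yl, a pyridine ring, or a phenyl ring carrying a methoxy group or an amine, and so whether the lower numbers extend beyond 4-fluorophenyl and thiophen-2-yl. Going by these compounds, all three compounds also share the rest of the core of compound 1, so it remains open whether these steps would keep their size if that core were changed elsewhere.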